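A few compounds are considered here, and "the series" means these few. Any claim that something is new, unique, unknown or untested is made for them only; others in the source may bear on it.

Compound 1 `O=C(NCCCNc1cc(-c2cn(-c3ccccc3)nc2-c2cccc(O)c2)ccn1)Nc1ccc(F)cc1` and compound 2 `O=C(NCCCNc1cc(-c2cn(-c3ccccc3)nc2-c2cccc(O)c2)ccn1)Nc1cccc(C(F)(F)F)c1` share one core and differ only on an amide-type nitrogen. In a functional assay on NCI/ADR-RES cells (Homo sapiens) for antiproliferative activity, read by sulforhodamine B assay, with a stated time of 48 h (a lower number here means a stronger inhibitor of growth, a higher number a weaker inhibitor of growth), compound 1 gives 12500 nM and compound 2 gives 12800 nM. Among the measured compounds shown here, these two values lie within the scatter of each other, so compound 1 stands level with its only neighbour. Compound 3 `COc1cccc(-c2nn(-c3ccccc3)cc2-c2ccnc(NCCCNC(=O)Nc3ccc(F)cc3)c2)c1` departs from compound 1 elsewhere: methyl in place of hydrogen on an oxygen on an aromatic ring, which turns hydroxy into methoxy, or 3-hydroxyphenyl into 3-methoxyphenyl. For the measured compounds named here, the only measured step, a 1.0-fold higher number from compound 1 to compound 2 (0.01 log units; within the scatter), concerns another place in the molecule, so it bears on this change only indirectly. Going by the values given here, no measured compound carries the methoxy group, and the direction of any shift remains open. No step beyond the scatter is therefore expected, and the expected step is a 1.1-fold higher number from compound 1 to compound 3 (0.05 log units; within the scatter). For compound 3, the estimated value is 14000 nM, with an expected range from 6000 nM to 35000 nM.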

Compound 3, concentration for total growth inhibition: 25400 nM
Estimate against measurement, compound 3: 1.8-fold (0.26 log units) below; the range from low to high includes it.
By their numbers in this assay, from the lowest: compounds 1, 2 and 3 (each within the scatter of the next, the first and the last beyond it).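

In this assay, methyl in place of hydrogen on the oxygen on the aromatic ring gives a 2.0-fold higher number from compound 1 to compound 3 (0.31 log units; beyond the scatter), a modest step towards weaker growth inhibition. Among the compounds shown here, the earlier pair, with its step of a 1.0-fold higher number from compound 1 to compound 2 (0.01 log units; within the scatter), showed only that the change on the amide-type nitrogen stayed within the scatter, whereas this oxygen is the first place where a single change moves the number beyond it. No available evidence accounts for this shift.

The compounds shown leave open whether an ethoxy group on this ring, or an amine or a carboxylic acid in place of the hydroxy, would shift the number further or return it towards that of compound 1. They also leave open whether the same step from hydroxy to methoxy would hold with the 3-(trifluoromethyl)phenyl group of compound 2.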